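The source may hold more compounds than are shown below. What is called first, only, known or untested is meant among the compounds shown, and "the series" means these compounds.

Compound 1 `Cc1ccc(NC(=O)Nc2cccc(CNc3ncnc4ccccc34)c2)cc1` — > 50000 nM
Compound 2 `O=C(Nc1cccc(Cl)c1)Nc1cccc(CNc2ncnc3ccccc23)c1` — > 50000 nM
Compound 3 `COc1ccc(NC(=O)Nc2cccc(CNc3ncnc4cc(OC)c(OC)cc34)c2)cc1` — > 50000 nM

In a functional assay on HepG2 cells (Homo sapiens) for antiproliferative activity, read by MTT assay (on this read-out higher numbers stand for weaker inhibition and lower numbers for stronger inhibition), compound 1 gives > 50000 nM, which is a limit of the assay rather than a number. Compound 2 gives > 50000 nM, likewise a limit. Compound 3 gives > 50000 nM, again a limit. All three values therefore sit at the limit of > 50000 nM in this assay, at which 3 of the 3 values shown sit, and nothing places any of the three above or below the others. Within the data shown here, the single step between two compounds that differ in one place, a step that the two limits leave unreadable from compound 1 to compound 2, cannot be read, since both ends are limits.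

Compound 4 `COc1cc2ncnc(NCc3cccc(NC(=O)Nc4ccccc4Cl)c3)c2cc1OC` is the next member. It differs from compound 3 by 2-chlorophenyl in place of 4-methoxyphenyl on an amide-type nitrogen. Among the measured compounds shown here, the only measured step that resembles this change, from compound 1 to compound 2, exchanged a 4-methylphenyl for a 3-chlorophenyl on the same kind of nitrogen and gave no readable size. With compound 3 itself standing at a limit, the step from compound 3 to compound 4 is expected to be a number no higher from compound 3 to compound 4 (the limit leaves the size open), that is, nothing that the assay can resolve. Compound 4 is accordingly estimated at 50000 nM, within a range from 15000 nM to 150000 nM, with a further limit the most likely outcome.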

Compound 4, half-maximal inhibitory concentration: 25500 nM
Compound 4: the middle estimate sits 2.0-fold (0.29 log units) above what was measured, and the stated range covers the measured number.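

Replacing 4-methoxyphenyl with 2-chlorophenyl on an amide-type nitrogen gives an at least 1.9-fold lower number from compound 3 to compound 4 (0.29 log units; that floor lies within the scatter) in this assay, and this is the only step shown with a readable size, though only as a floor that does not clear the usual scatter. On these data alone, compound 4 gives 25500 nM, a measured number that shows this substituent on the shared core can bring the read-out within the range of the assay, while the true size of the change remains unknown. Compound 1, compound 2 and compound 3 each stay at a limit, which is why compound 4 has no measured number to be set against: the limit of > 50000 nM in this assay, at which 3 of the 4 values shown sit.

The compounds shown leave open whether this result depends on the chlorine itself, on its place in the 2-chlorophenyl group or on the loss of the 4-methoxyphenyl group, and whether a 2-fluorophenyl, 2-methylphenyl or 2-aminophenyl group on the same nitrogen would give a similar value. They also leave open whether 2-chlorophenyl would give a measurable value on the core of compound 1.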